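A few compounds are considered here, and "the series" means these few. Any claim that something is new, unique, unknown or untested is made for them only; others in the source may bear on it.

Compound 1 `O=C(COc1c(-c2ccccc2)oc2ccccc2c1=O)Nc1ccccc1` is the reference point. In a functional assay on MT2 cells (Homo sapiens) for antiproliferative activity, read by MTT assay, with a stated time of 72 h (a lower number here means a stronger inhibitor of growth, a higher number a weaker inhibitor of growth), compound 1 gives 6720 nM. Compound 2 `O=C(COc1c(-c2ccccc2)oc2ccccc2c1=O)Nc1ccc(F)cc1` carries the change (fluoro in place of hydrogen on an aromatic carbon). For compound 2 this assay reports only a limit, > 10000 nM. The step of an at least 1.4-fold higher number from compound 1 to compound 2 (0.17 log units; that floor lies within the scatter) therefore rests on a limit at one end, and its size cannot be fixed more closely than that; the account of the limit of > 10000 nM in this assay, at which 2 of the 3 values shown sit, bears on it.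

Compound 3 `O=C(COc1ccc2c(=O)cc(-c3ccccc3)oc2c1)Nc1ccccc1` has a different core; how the two cores differ is not broken down here. For compound 3 this assay again reports only a limit, > 10000 nM.

Compound 4 `O=C(COc1ccc2c(=O)cc(-c3ccccc3)oc2c1)Nc1ccc(F)cc1` has not been measured. It stands to compound 3 as compound 2 stands to compound 1, through the same change, (fluoro in place of hydrogen on an aromatic carbon). Since compound 3 already sits at the limit of this assay, and since the same change gave an at least 1.4-fold higher number from compound 1 to compound 2 (0.17 log units; that floor lies within the scatter), compound 4 is expected to remain at or beyond that limit, the expected step being a step that the limit leaves unreadable from compound 3 to compound 4. For compound 4 the estimate is 16000 nM, between 8000 nM and 40000 nM.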

Compound 4, concentration for 50% growth inhibition: 6410 nM
Compound 4: the middle estimate sits 2.5-fold (0.40 log units) above what was measured; the measured number lies below the stated range.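

Carrying fluoro in place of hydrogen over to the second core gives, in this assay, an at least 1.5-fold lower number from compound 3 to compound 4 (0.19 log units; that floor lies within the scatter), and this step is a floor and not a full size. The two steps are printed in opposite directions, yet this does not show that the change acts differently on the two cores, nor does it show that the change acts alike on them: the same change on two cores in this assay, an at least 1.4-fold higher number (0.17 log units; that floor lies within the scatter) from compound 1 to compound 2 and an at least 1.5-fold lower number (0.19 log units; that floor lies within the scatter) from compound 3 to compound 4; the limit leaves it open whether they differ Each step has a limit at one end, so neither size can be fixed, and that limit recurs across the set: the limit of > 10000 nM in this assay, at which 2 of the 4 values shown sit.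

The compounds shown leave open whether a group other than fluoro on the anilino ring, such as chloro, methoxy or a carboxylic acid, would follow the same course on either core, and whether fluoro in another place on that ring would do so. They also leave open what an amine on that ring, or a longer chain joining the core to the anilino group, would give.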